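The source may hold more compounds than are shown below. What is called first, only, known or untested is meant among the compounds shown, and "the series" means these compounds.

Measured compounds in an ADME assay on the whole organism for metabolic stability, with Mus musculus as the target, read by HPLC, at a dose of 10 mg/kg by the oral route; a lower number here means that the compound disappears faster, a higher number that the compound lasts longer:
compound 1 `COC(=O)N[C@H](C(=O)N1CCC[C@H]1C(=O)Nc1ccc([C@@H]2CC[C@@H](c3ccc(NC(=O)[C@@H]4CCCN4C(=O)[C@@H](NC(=O)OC)C(C)C)cc3)N2c2ccc([Si](C)(C)C)cc2)cc1)C(C)C`, which gives 8.8 h
compound 2 `CC[Si](CC)(CC)c1ccc(N2[C@H](c3ccc(NC(=O)[C@@H]4CCCN4C(=O)[C@@H](NC(=O)OC)C(C)C)cc3)CC[C@H]2c2ccc(NC(=O)[C@@H]3CCCN3C(=O)[C@@H](NC(=O)OC)C(C)C)cc2)cc1`, which gives 22.5 h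

For the measured compounds named here, compound 1 holds the lower of the two numbers in this assay; its only neighbour, compound 2, stands apart from it by a 2.6-fold higher number from compound 1 to compound 2 (0.41 log units; beyond the scatter). That step exchanges the group on the aromatic carbon of the shared core, the silicon-bearing group gaining three carbons spread over its three arms.

Compound 3 `COC(=O)N[C@H](C(=O)N1CCC[C@H]1C(=O)Nc1ccc([C@@H]2CC[C@@H](c3ccc(NC(=O)[C@@H]4CCCN4C(=O)[C@@H](NC(=O)OC)C(C)C)cc3)N2c2ccc([Si](C)(C)C(C)(C)C)cc2)cc1)C(C)C` is not yet measured. It differs from compound 1 by tert-butyl in place of methyl on a silicon. Going by the values given here, the only measured step that bears on it is the one from compound 1 to compound 2, where the silicon-bearing group likewise grew by three carbons, and the number rose modestly, beyond the scatter. Compound 3 grows by the same count of carbons but on a single arm of the silicon, so the same direction is expected, with a size that may fall anywhere from within the scatter up to the size seen for compound 2. For compound 3 a half-life of 15 h is therefore estimated, within 7 h to 30 h, which would mean an expected step of a 1.7-fold higher number from compound 1 to compound 3 (0.23 log units; within the scatter).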

Compound 3, half-life: 34.7 h
For compound 3 the middle estimate is 2.3-fold (0.36 log units) below the measured one; the measured number lies above the stated range.
By their numbers in this assay, from the lowest: compound 1; then compounds 2 and 3 (each within the scatter of the next).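

In this assay, tert-butyl in place of methyl on a silicon gives a 3.9-fold higher number from compound 1 to compound 3 (0.60 log units; beyond the scatter) and so shows that a change on a single arm of the silicon is enough to move the number beyond the scatter, whereas the earlier pair showed only a change spread over all three arms. The silicon-bearing groups of compound 2 and compound 3 have the same count of heavy atoms, and a 1.5-fold higher number from compound 2 to compound 3 (0.19 log units; within the scatter) means that these two arrangements are not told apart in this assay, so among these three compounds both larger groups stand above the trimethylsilyl-type group of compound 1, and none goes against this. No supporting data on the compounds are available to explain the rise from compound 1.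

The compounds shown leave open whether silicon itself matters, which a plain tert-butyl on the aromatic carbon would test, and whether the number keeps rising with a still larger group on the silicon, such as a phenyl or a longer chain. They also leave open how an amine or a carboxylic acid on one arm of the silicon would read in this assay.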